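This account rests on a few compounds, and the source may have more. Where it says the series, first, only, none or still open, it means among the compounds named here.

Of the compounds shown here, three sharing one core have been tested in an ADME assay on NIH3T3 cells (Mus musculus) for cytotoxicity, read by MTT assay, with a stated time of 24 h; a higher number here means a weaker inhibitor, a lower number a stronger inhibitor. Compound 1 `Cn1cnnc1SCCc1nnc(SCC(=O)Nc2nc3ccc(F)cc3s2)o1` reaches only the limit of the test, > 500 ug/mL. Compound 2 `Cn1cnnc1SCCc1nnc(SCC(=O)Nc2ccc(F)cc2)o1` likewise stops at a limit, > 500 ug/mL. Compound 3 `Cn1cnnc1SCCc1nnc(SCC(=O)Nc2ccc(Cl)cc2)o1` also stops at a limit, > 500 ug/mL. Among the compounds with values here, the single step among them, a step that the two limits leave unreadable from compound 2 to compound 3, cannot be sized because of the limit of > 500 ug/mL in this assay, at which 3 of the 3 values shown sit. Compound 4 `Cn1cnnc1SCCc1nnc(SCC(=O)Nc2nc3ccccc3s2)o1` differs from compound 3 by 1,3-benzothiazol-2-yl in place of 4-chlorophenyl on an amide-type nitrogen. Within the data shown here, no measured step bears directly on this change, and none of the values separates any two compounds, so compound 4 is expected to sit at the limit as well, with a step that the limit leaves unreadable from compound 3 to compound 4 not readable beyond the scatter. The estimate for compound 4 in this assay is 600 ug/mL, within 250 ug/mL to 2000 ug/mL.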

Compound 4, half-maximal inhibitory concentration: > 500 ug/mL
Compound 4: no number, only a limit (the forecaster's own chance of this, stated with the estimate: 85%); the middle value lies beyond the limit too.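

Within the data shown here, no step from compound 1, compound 2 or compound 3 to compound 4 can be read, because all four stop at a limit: the limit of > 500 ug/mL in this assay, at which 4 of the 4 values shown sit. The compounds shown leave open whether any of these changes shifts the true value in this assay at all.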